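A few compounds are considered here, and "the series" means these few. Any claim that something is new, unique, unknown or untested is made for them only; others in the source may bear on it.

Measured so far:
compound 1 `CCN(Cc1cncs1)C(=O)COc1ccc(C)cc1`, 1100 nM
compound 2 `CCN(Cc1cccnc1)C(=O)COc1ccc(C)cc1`, 15400 nM
compound 3 `CCN(Cc1cccs1)C(=O)COc1ccc2c(c1)CCC2`, 0.8 nM

All three were tested in an assay on HEK293 cells for agonist activity at transient receptor potential cation channel subfamily M member 8 (Homo sapiens), read by fluorescence and calcium flux, with a stated time of 15 min; a lower number here means that less compound is needed, a higher number that more compound is needed for the effect. Among these three numbers compound 2 stands highest: compound 1 lies nearest to it, while compound 3, which also carries a different core, lies furthest away. Going by the values given here, the only step measured within one core that touches the same part of the molecule is the one from compound 1 to compound 2, where a ring on the saturated chain carbon bound to the amide-type nitrogen was exchanged: a 14-fold higher number from compound 1 to compound 2 (1.15 log units; beyond the scatter). That single step shows that this ring matters for the read-out.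

Compound 4 `CCN(Cc1ccccc1)C(=O)COc1ccc(C)cc1` has not been measured yet. It differs from compound 2 in one place: phenyl in place of pyridin-3-yl on a saturated chain carbon bound to an amide-type nitrogen. Among the compounds with values here, no measured step swaps a six-membered ring for another six-membered ring at this position, so the expectation rests only on the step from compound 1 to compound 2, which shows that a change of ring here moved the number well beyond the scatter. The expected direction is a lower number, back toward compound 1, but with wide uncertainty. For compound 4 the estimate in this assay is 2000 nM, within 300 nM to 12000 nM, meaning an expected step of a 7.7-fold lower number from compound 2 to compound 4 (0.89 log units; beyond the scatter).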

Compound 4, half-maximal effective concentration: 1880 nM
Compound 4: middle estimate off by 1.1-fold (0.03 log units), on the high side; the measured number falls inside the stated range.
By their numbers in this assay, from the lowest: compound 3; then compounds 1 and 4 (each within the scatter of the next); then compound 2.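

In this assay, putting phenyl in place of pyridin-3-yl on the saturated chain carbon bound to the amide-type nitrogen gives an 8.2-fold lower number from compound 2 to compound 4 (0.91 log units; beyond the scatter) and so shows that a modest edit can matter here: both groups have six heavy atoms, and one ring nitrogen gives way to carbon. Putting phenyl in place of 1,3-thiazol-5-yl at the same place gives a 1.7-fold higher number from compound 1 to compound 4 (0.23 log units; within the scatter) and leaves compound 1 and compound 4 indistinguishable in this read-out, so a ring at this position does not have to be one particular ring to give a number of that size. Among these three rings pyridin-3-yl alone stands apart, yet this is no simple rule against hetero atoms in the ring, since compound 1 goes against such a rule by carrying them in its 1,3-thiazol-5-yl group.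

On these data alone, what an amine, a carboxylic acid or a longer chain between the ring and the amide-type nitrogen would do at this position remains open. Nothing available explains why pyridin-3-yl differs from the other two rings.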